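A Pyrimidinyl Ring Weighed Against a Dihydropyranyl Baseline

The source may hold more compounds than are shown below. What is called first, only, known or untested is meant among the compounds shown, and "the series" means these compounds.

Among the compounds with values here, compound 2 `Cc1cc(NCc2ccccn2)n2ncc(C3=CCOCC3)c2n1` gives the only number reported in a physicochemical assay for solubility, read by HPLC, using the shake flask method, measured as kinetic solubility, with a stated time of 2 h, at pH 7.4 (on this read-out higher numbers stand for higher solubility and lower numbers for lower solubility), namely 171000 nM. Compound 1 `Cc1cc(NCc2ccccn2)n2ncc(-c3cc(F)c(F)c(F)c3)c2n1` is reported in this assay only as a limit, < 5000 nM. Within the data shown here, the one measured step, an at least 34-fold higher number from compound 1 to compound 2 (1.53 log units; beyond the scatter), is large. Since compound 1 sits at the limit (the limit of < 5000 nM in this assay, at which 1 of the 2 values shown sits), the true size of that step is not fixed. Compound 3 `Cc1cc(NCc2ccccn2)n2ncc(-c3cncnc3)c2n1` differs from compound 2 by a group of 6 heavy atoms (4 carbon, 2 nitrogen; one six-membered aromatic ring with 2 hetero atoms) in place of a group of 6 heavy atoms (5 carbon, 1 oxygen; one six-membered non-aromatic ring with 1 hetero atom), on an aromatic carbon. This change leaves the non-aromatic ring of compound 2 behind and returns to a six-membered aromatic ring, though one carrying nitrogen rather than fluorine, so the step from compound 1 to compound 2 bears on it only in part. The solubility of compound 3 is expected to fall somewhat from that of compound 2, an estimated step of a 2.9-fold lower number from compound 2 to compound 3 (0.45 log units; beyond the scatter). Compound 3 is accordingly estimated at 60000 nM, with a range from 15000 nM to 200000 nM.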

Compound 3, solubility: 111000 nM
Compound 3: middle estimate off by 1.9-fold (0.27 log units), on the low side; the measured number falls inside the stated range.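

In this assay, the replacement at this aromatic carbon of the five-membered ring gives a 1.5-fold lower number from compound 2 to compound 3 (0.19 log units; within the scatter), so the pyrimidin-5-yl group of compound 3 and the non-aromatic ring of compound 2 cannot be told apart on this read-out. The second new comparison keeps a six-membered aromatic ring at this place and exchanges only the ring itself, with pyrimidin-5-yl in place of 3,4,5-trifluorophenyl: an at least 22-fold higher number from compound 1 to compound 3 (1.34 log units; beyond the scatter). Compound 1 is reported only as a limit, so the true size of that step remains unfixed: the limit of < 5000 nM in this assay, at which 1 of the 3 values shown sits.

The compounds shown leave open where an unsubstituted phenyl ring or a pyridin-3-yl ring would fall at this position. They also leave open how a morpholine or a carboxylic acid on this carbon would read.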